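A few compounds are considered here, and "the series" means these few. Any claim that something is new, unique, unknown or untested is made for them only; others in the source may bear on it.

Compound 1, with the structure `C=C(C)[C@@H]1CC=C(Cn2cc(COc3ccc(C4NC(=O)NC(C)=C4C(=O)OCC)cc3)nn2)CC1`, and compound 2, with the structure `C=C(C)[C@@H]1CC=C(Cn2cc(COc3ccccc3C3NC(=O)NC(C)=C3C(=O)OCC)nn2)CC1`, share the same atoms but have them joined differently; the difference between the two cores is not broken down here. In a functional assay on 786-0 cells (Homo sapiens) for inhibition, read by sulforhodamine B assay, with a stated time of 48 h (a higher number here means a weaker inhibitor of growth, a lower number a stronger inhibitor of growth), compound 1 gives 97100 nM. In this assay compound 2 gives > 100000 nM, which is a limit of the assay rather than a number, (the limit of > 100000 nM in this assay, at which 1 of the 3 values shown sits). Compound 3, with the structure `C=C(C)[C@@H]1CC=C(Cn2cc(COc3ccc(C4NC(=O)NC(C)=C4C(C)=O)cc3)nn2)CC1`, keeps the core of compound 1 but carries methyl in place of ethoxy on a carbonyl carbon. In this assay compound 3 gives 23300 nM, and the step of a 4.2-fold lower number from compound 1 to compound 3 (0.62 log units; beyond the scatter) lies beyond the scatter. Compound 4, with the structure `C=C(C)[C@@H]1CC=C(Cn2cc(COc3ccccc3C3NC(=O)NC(C)=C3C(C)=O)nn2)CC1`, has not yet been measured; it carries the same change on the core of compound 2, namely (methyl in place of ethoxy on a carbonyl carbon), at a place described in the same words as for compound 3. On the strength of the measured step from compound 1 to compound 3, the step expected from compound 2 to compound 4 is an at least 1.6-fold lower number from compound 2 to compound 4 (0.22 log units; that floor lies within the scatter). Compound 4 is therefore estimated to give about 60000 nM in this assay, somewhere between 20000 nM and 150000 nM, though the starting point is only a limit.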

Compound 4, concentration for total growth inhibition: 80300 nM
The estimate for compound 4 lay 1.3-fold (0.13 log units) below the measured number; the range from low to high includes it.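

Carried to the second core, the swap from ethoxycarbonyl to acetyl gives, in this assay, an at least 1.2-fold lower number from compound 2 to compound 4 (0.09 log units; that floor lies within the scatter), and that size is only a floor for the true step. Compound 2 gives > 100000 nM, which is a limit of the assay and not a number. The change can therefore be set beside its counterpart on the first core, but this pair neither confirms nor rules out that it carries over with the same size: the same change on two cores in this assay, a 4.2-fold lower number (0.62 log units; beyond the scatter) from compound 1 to compound 3 and an at least 1.2-fold lower number (0.09 log units; that floor lies within the scatter) from compound 2 to compound 4; the limit leaves it open whether they differ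

The compounds shown leave open what an actual number for compound 2 would be, and so how large the step on this core really is. They also leave open how other groups would behave on the carbonyl carbon, whose other neighbour is the double-bonded ring carbon, for example an amide, a carboxylic acid or a longer chain than the methyl of the acetyl group.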